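Methyl on the sulfur of compound 3

A few compounds are considered here, and "the series" means these few. Any claim that something is new, unique, unknown or untested is made for them only; others in the source may bear on it.

Compound 3 `Sc1nc(NCc2ccccc2)c2ccccc2n1` carries a hydrogen on its sulfur. In a functional assay on CCRF-CEM cells (Homo sapiens) for cytotoxicity, read by MTT assay, with a stated time of 72 h (on this read-out lower numbers stand for stronger inhibition of growth and higher numbers for weaker inhibition of growth), compound 3 gives 82400 nM, the highest of the two numbers in hand. Going by the values given here, its nearest neighbour is compound 2 `CCCCC[Se]c1nc(NCc2ccccc2)c2ccccc2n1`, which in this assay gives 34500 nM; the step of a 2.4-fold higher number from compound 2 to compound 3 (0.38 log units; beyond the scatter) is the only measured step in the set and lies beyond the scatter. Compound 1 `CSc1nc(NCCCCCO)c2ccccc2n1` shares the methylsulfanyl group of compound 4 but carries a different amine. In this assay compound 1 gives > 100000 nM, which is a limit of the assay and not a number (the limit of > 100000 nM in this assay, at which 1 of the 3 values shown sits).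

Compound 4 `CSc1nc(NCc2ccccc2)c2ccccc2n1` differs from compound 3 by methyl in place of hydrogen on a sulfur. Among the compounds with values here, the one measured step, from compound 2 to compound 3, concerns the same sulfur: exchanging the larger group on that aromatic carbon for a bare sulfur raised the number modestly. Compound 4 puts a carbon back on that sulfur, so the step is expected to run the other way, small, at most about the size of the measured one, possibly within the scatter. Within the data shown here, the value of compound 1 shows only that a methylsulfanyl group with another amine gave a limit; no step follows from it. For compound 4 the expected step is a 1.4-fold lower number from compound 3 to compound 4 (0.14 log units; within the scatter), and compound 4 is estimated at 60000 nM (range 20000 nM to 150000 nM).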

Compound 4, concentration for 50% growth inhibition: 87900 nM
Estimate against measurement, compound 4: 1.5-fold (0.17 log units) below; the range from low to high includes it.
By their numbers in this assay, from the lowest: compound 2; then compounds 3 and 4 (each within the scatter of the next). At a limit, above all of these: compound 1.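

In this assay, methyl in place of hydrogen on the sulfur whose other neighbour is an aromatic carbon gives a 1.1-fold higher number from compound 3 to compound 4 (0.03 log units; within the scatter), so the two compounds read as one level. The earlier step could not show whether any carbon group on this atom would bring the number down, but with a 2.5-fold higher number from compound 2 to compound 4 (0.41 log units; beyond the scatter) the methylsulfanyl compound stays apart from compound 2 by a modest step beyond the scatter, on the same side as the bare sulfur of compound 3. Phenyl in place of 4-hydroxybutyl on a saturated chain carbon bound to a nitrogen on an aromatic ring gives an at least 1.1-fold lower number from compound 1 to compound 4 (0.05 log units; that floor lies within the scatter), a step that starts from a limit and gives only a floor. Compound 1 stands at a limit of the assay, not a number: the limit of > 100000 nM in this assay, at which 1 of the 4 values shown sits.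

Compound 2 differs from compounds 3 and 4 in both the chain and the selenium, so the modest step to compound 2 cannot be assigned to either one; a pentyl chain on sulfur and a methyl on selenium would separate the two. On these data alone, how the number responds to a chain of intermediate length on this sulfur, or to a chain ending in a hydroxyl or a carboxylic acid, also remains open.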